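Chloro on the fused ring of compound 2

The source may hold more compounds than are shown below. What is called first, only, known or untested is meant among the compounds shown, and "the series" means these compounds.

Measured compounds:
- compound 1 `O=S(=O)(c1ccccc1)c1cn(C2CCNC2)c2ccccc12`: 5 nM
- compound 2 `O=S(=O)(c1cccc(F)c1)c1cn(C2CCNC2)c2ccccc12`: 4.7 nM
- compound 3 `O=S(=O)(c1cccc(F)c1)c1cn(C2CCNC2)c2cccc(F)c12`: 18 nM

In an assay on HeLa cells for displacement of a labelled ligand from 5-hydroxytryptamine receptor 6 (Homo sapiens), with a stated time of 2 h (on this read-out higher numbers stand for weaker inhibition and lower numbers for stronger inhibition), compound 2 gives 4.7 nM, the lowest of the three numbers; its gap to compound 1 lies within the scatter, while compound 3 sits a 3.8-fold higher number from compound 2 to compound 3 (0.58 log units; beyond the scatter) away. Compound 4 `O=S(=O)(c1cccc(F)c1)c1cn(C2CCNC2)c2cc(Cl)ccc12` differs from compound 2 by chloro in place of hydrogen on an aromatic carbon. Among the compounds with values here, two measured steps bear on this change, both a halogen entering an aromatic carbon: from compound 1 to compound 2 the number hardly moved, a 1.1-fold lower number from compound 1 to compound 2 (0.03 log units; within the scatter), whereas the change from compound 2 to compound 3, on the same fused ring as the change now considered, gave a 3.8-fold higher number from compound 2 to compound 3 (0.58 log units; beyond the scatter). Because compound 3 shows a 3.8-fold higher number from compound 2 to compound 3 (0.58 log units; beyond the scatter) for a halogen on that ring, a modest rise in this assay is expected for compound 4 rather than none, though the position differs and the size is uncertain. Compound 4 is therefore estimated at 9 nM (range 3 nM to 28 nM), which means an expected step of a 1.9-fold higher number from compound 2 to compound 4 (0.28 log units; within the scatter).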

Compound 4, inhibition constant: 72 nM
Beside the measured number, compound 4's estimate is 8.0-fold (0.90 log units) below it, outside the stated range (above it).
By their numbers in this assay, from the lowest: compounds 2 and 1 (each within the scatter of the next); then compound 3; then compound 4.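

In this assay, within the data shown here, the fused ring proves far less forgiving of a halogen than the earlier compounds showed, with a 15-fold higher number from compound 2 to compound 4 (1.19 log units; beyond the scatter) for chloro in place of hydrogen on an aromatic carbon meta to a fused ring and para to a fused ring. This step is larger than both earlier halogen steps, a 3.8-fold higher number from compound 2 to compound 3 (0.58 log units; beyond the scatter) on the same fused ring and a 1.1-fold lower number from compound 1 to compound 2 (0.03 log units; within the scatter) on the other aromatic ring, so entry of a halogen on the fused ring does not give one fixed shift in this read-out. No available evidence bears on what lies behind the size of this step.

The compounds shown leave open whether the large rise belongs to chloro itself or to this carbon, as the halogen and its position both differ between the two steps on the fused ring. Fluoro at this same carbon would address that, while a methyl, a methoxy or an amine there would show whether the rise is confined to halogens.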